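The source may hold more compounds than are shown below. What is called first, only, known or untested is meant among the compounds shown, and "the series" means these compounds.

This series shares one core and was examined in a functional assay on C6 cells (Rattus norvegicus) for cytotoxicity, read by MTT assay, with a stated time of 24 h, tested at 6 ug/mL; a higher number here means a weaker effect of the compound at the concentration tested, a lower number a stronger effect. Compound 1 `Cn1nnnc1SCC(=O)N/N=c1/scc(-c2ccc(C#N)cc2)n1-c1ccccc1` gives 63.5%. Among the measured compounds shown here, compound 2 `Cn1nnnc1SCC(=O)N/N=c1/scc(-c2ccc([N+](=O)[O-])cc2)n1-c1ccccc1` gives 80.4%, and the one measured step, a number 16.9 percentage points higher from compound 1 to compound 2 (beyond the scatter), separates these two. Compound 3 `Cn1cnnc1SCC(=O)N/N=c1/scc(-c2ccccc2)n1-c1ccccc1` gives 90%, the highest of the three numbers; its nearest neighbour is compound 2, whose number lies within the scatter of compound 3, while compound 1 stands furthest away, beyond the scatter.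

Compound 4 `Cn1nnnc1SCC(=O)N/N=c1/scc(-c2ccccc2)n1-c1ccccc1` differs from compound 3 in one place: 1-methyl-1H-tetrazol-5-yl in place of 4-methyl-4H-1,2,4-triazol-3-yl on a sulfur. For the measured compounds named here, no measured step touches this exchange, since the step from compound 1 to compound 2 concerns the group on the aromatic carbon and compounds 1 and 2 both already carry the 1-methyl-1H-tetrazol-5-yl group. Nothing measured therefore speaks for a shift beyond the scatter, and the step from compound 3 to compound 4 is expected to be about a number 10 percentage points lower from compound 3 to compound 4 (within the scatter). Compound 4 is accordingly estimated at 80%, with a likely range from 62% to 98%.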

Compound 4, a percentage reported as activity, at one concentration (the size of the read-out at that concentration, not a potency): 85.2%
Compound 4: middle estimate off by 5.2 percentage points, on the low side; measured number inside the range.
By their numbers in this assay, from the lowest: compound 1; then compounds 2, 4 and 3 (each within the scatter of the next).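

In this assay the exchange of 4-methyl-4H-1,2,4-triazol-3-yl for 1-methyl-1H-tetrazol-5-yl on the sulfur gives a number 4.8 percentage points lower from compound 3 to compound 4 (within the scatter) and so does not separate these two groups at this position. Compound 4 also gives the aromatic carbon a hydrogen comparison: hydrogen in place of nitro gives a number 4.8 percentage points higher from compound 2 to compound 4 (within the scatter) while hydrogen in place of cyano gives a number 21.7 percentage points higher from compound 1 to compound 4 (beyond the scatter) and thus only the cyano compound stands apart from the hydrogen compound. No evidence is available to explain these results.

On these data alone, it remains open whether the cyano step would hold with 4-methyl-4H-1,2,4-triazol-3-yl on the sulfur. Also open, as far as these compounds go, is how an amine or a carboxylic acid on the aromatic carbon would read in this assay.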